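This account rests on a few compounds, and the source may have more. Where it says the series, first, only, none or still open, it means among the compounds named here.

Three compounds share one core and differ only in the group at its far end. Compound 1 `CC#CC(CC(=O)O)c1ccc(OCc2ccn3cc(-c4ccc(C5CCCCC5)cc4)nc3c2)cc1` gives 559 nM in an assay on isolated protein for agonist activity at Free fatty acid receptor 1 (Homo sapiens); on this read-out higher numbers stand for an effect only at larger amounts of compound and lower numbers for an effect already at smaller amounts. Compound 2 `CC#CC(CC(=O)O)c1ccc(OCc2ccn3cc(-c4cccc(C)c4)nc3c2)cc1` gives 1510 nM in this assay, and compound 3 `CC#CC(CC(=O)O)c1ccc(OCc2ccn3cc(-c4ccc(C(F)(F)F)cc4)nc3c2)cc1` gives 674 nM. On these numbers compound 3 stands second highest of the three: a 1.2-fold higher number from compound 1 to compound 3 (0.08 log units; within the scatter), whereas a 2.2-fold lower number from compound 2 to compound 3 (0.35 log units; beyond the scatter). Compound 4 `CC#CC(CC(=O)O)c1ccc(OCc2ccn3cc(-c4ccc(F)cc4)nc3c2)cc1` carries fluoro in place of trifluoromethyl on an aromatic carbon. Going by the values given here, no measured step tries fluoro itself; the nearest comparisons, a 1.2-fold higher number from compound 1 to compound 3 (0.08 log units; within the scatter) and a 2.2-fold lower number from compound 2 to compound 3 (0.35 log units; beyond the scatter), show that exchanging this end group moves the number only modestly. The step of a 1.5-fold higher number from compound 3 to compound 4 (0.17 log units; within the scatter) is therefore expected to be small, more likely toward a higher number. Compound 4 is expected to give about 1000 nM, between 400 nM and 2500 nM.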

Compound 4, half-maximal effective concentration: 783 nM
Compound 4: middle estimate off by 1.3-fold (0.11 log units), on the high side, within the range that was stated.
By their numbers in this assay, from the lowest: compounds 1, 3, 4 and 2 (each within the scatter of the next, the first and the last beyond it).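

Replacing trifluoromethyl with a single fluoro leaves the two numbers indistinguishable in this assay, with a 1.2-fold higher number from compound 3 to compound 4 (0.07 log units; within the scatter). Fluoro also cannot be told apart from cyclohexyl, with a 1.4-fold higher number from compound 1 to compound 4 (0.15 log units; within the scatter), or from the 3-methylphenyl end group, with a 1.9-fold lower number from compound 2 to compound 4 (0.29 log units; within the scatter), so this position accepts a single fluorine atom as readily as a whole cyclohexyl ring on this read-out. No measurement here explains this tolerance. On these data alone, what an amine or a carboxylic acid on this aromatic carbon would do remains open.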